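The source may hold more compounds than are shown below. What is called first, only, known or untested is meant among the compounds shown, and "the series" means these compounds.

In an ADME assay on TZM cells (Homo sapiens) for cytotoxicity, read by CCK-8 assay, with a stated time of 2 days (a higher number here means that more compound is tolerated, a lower number that less compound is tolerated), two compounds have been measured so far:

compound 1 (`CC(=O)Oc1ccc(/C=C/S(=O)(=O)CCc2ccc(NC(=O)c3ccc(F)cc3)cc2)cc1OC(C)=O`) gives 162000 nM as its value
compound 2 (`COc1ccc(C(=O)Nc2ccc(CCS(=O)(=O)/C=C/c3ccc(O)c(O)c3)cc2)cc1`) gives > 1000000 nM as its value

The entry for compound 2 is a limit of the assay and not a number. The record for compound 2 is therefore the limit of > 1000000 nM in this assay, at which 1 of the 2 values shown sits, and no exact figure exists for it.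

Compound 3 (`O=C(Nc1ccc(CCS(=O)(=O)/C=C/c2ccc(O)c(O)c2)cc1)c1cc(F)cc(F)c1`) keeps the shared core of compound 2 and changes one group, with 3,5-difluorophenyl in place of 4-methoxyphenyl on a carbonyl carbon. Among the measured compounds shown here, no measured pair isolates this swap, since compound 1 and compound 2 differ in more than one place. The only exact reading is compound 1 at 162000 nM and it shows that an exact value can occur among these compounds, so a fall is expected for compound 3. A second limit, rather than a fall, remains possible for compound 3. The expected change, an at least 2.8-fold lower number from compound 2 to compound 3 (0.45 log units; beyond the scatter) and moderate in size, is downward and only an estimate. In this assay the estimated value for compound 3 is 350000 nM (expected range 100000 nM to 1000000 nM).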

Compound 3, half-maximal cytotoxic concentration: 414000 nM
For compound 3 the middle estimate is 1.2-fold (0.07 log units) below the measured one; the range from low to high includes it.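

In this assay, putting 3,5-difluorophenyl in place of 4-methoxyphenyl on a carbonyl carbon gives an at least 2.4-fold lower number from compound 2 to compound 3 (0.38 log units; beyond the scatter), and this is the only step among these compounds that isolates a single change. It shows that the group at this position matters for how much compound the cells tolerate, and that the shared core can give an exact reading with a group other than 4-methoxyphenyl here, as compound 3 gives 414000 nM. The step has a lower bound but no upper bound, since the entry for compound 2 is a limit of the assay and not a number: the limit of > 1000000 nM in this assay, at which 1 of the 3 values shown sits.

The swap removes the methoxy group and brings in two fluorine atoms in one move, so these compounds cannot say which part of it produces the fall, or whether a single fluorine would do the same. As far as these compounds go, how a plain phenyl, or a ring carrying an amine or a carboxylic acid, would behave on this carbonyl carbon remains open, as does the effect of this swap on any other core.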